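The compounds below may be only part of what the source reports. "The series", "measured", "known", "first", "only" and "open" are said of these compounds alone.

Working notes on the series. Compound 1 `N#Cc1cccc(C(=O)NC2CCCC(NC(=O)c3ccccn3)C2)c1` is the racemic parent; in a functional assay on HEK293 cells for antagonist activity at metabotropic glutamate receptor 5 (Homo sapiens), read by FLIPR and calcium flux (on this read-out higher numbers stand for weaker inhibition and lower numbers for stronger inhibition), compound 1 gives 531 nM, the highest number among the two measured. Among the measured compounds shown here, its single defined-configuration counterpart, compound 2 `N#Cc1cccc(C(=O)N[C@@H]2CCC[C@@H](NC(=O)c3ccccn3)C2)c1`, gives in this assay 231 nM; the step of a 2.3-fold lower number from compound 1 to compound 2 (0.36 log units; beyond the scatter) is the only measured step, and it rests on (the fact that one of compounds 1 and 2 is drawn with a defined configuration and the other without, at the place where they differ). Compound 3 `COc1cccc(C(=O)NC2CCCC(NC(=O)c3ccccn3)C2)c1` carries a different change from compound 1: methoxy in place of cyano on an aromatic carbon, the cyano leaving and the methoxy entering on the same aromatic carbon, with ring and core unchanged. For the measured compounds named here, no measured step in this assay touches an aromatic substituent, so the stereo step carries no weight for this change and there is no basis to expect a step beyond the scatter in either direction. The expected result for compound 3 in this assay is therefore 1000 nM, within 250 nM to 4000 nM, meaning an estimated step of a 1.9-fold higher number from compound 1 to compound 3 (0.27 log units; within the scatter).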

Compound 3, half-maximal inhibitory concentration: > 10000 nM
Compound 3 was reported as a limit; the forecaster's own chance of this, stated with the estimate: 10%; middle value at least 10-fold (1.00 log units) away from the limit.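

In this assay compound 3 is recorded as a limit, > 10000 nM, and not as a number. Methoxy in place of cyano on this aromatic carbon, meta to a large group, gives an at least 18-fold higher number from compound 1 to compound 3 (1.27 log units; beyond the scatter), so the position is far from indifferent to what it carries, even though the two groups match in heavy-atom count and hydrogen-bond acceptor count. The earlier stereo step said nothing about this place, and the full size of the new step remains unread: the limit of > 10000 nM in this assay, at which 1 of the 3 values shown sits.

Still open, from the compounds shown here alone, is whether this loss is specific to methoxy or follows any replacement of the nitrile, which a chlorine atom, a fluorine atom or a plain hydrogen on the same carbon would help to separate. Also open, going by these compounds, is whether the same change has a comparable effect with the configuration drawn in compound 2.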